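This account rests on a few compounds, and the source may have more. Where it says the series, first, only, none or still open, it means among the compounds named here.

Compound 1 `CN(C)CCCNc1nc(-c2ccc(NC(=O)Nc3ccccc3Cl)cc2)nc2c(Cl)c(Cl)sc12`: in a functional assay on HT-29 cells (Homo sapiens) for cytotoxicity, read by MTT assay, with a stated time of 72 h (on this read-out higher numbers stand for weaker inhibition and lower numbers for stronger inhibition), compound 1 gives 820 nM.
Compound 2 `CN(C)CCCNc1nc(-c2ccc(NC(=O)Nc3ccc(Cl)cc3Cl)cc2)nc2c(Cl)c(Cl)sc12`: in this assay compound 2 gives 1320 nM.

Of these two numbers compound 2 has the highest, with compound 1 nearest; the step of a 1.6-fold higher number from compound 1 to compound 2 (0.21 log units; within the scatter) lies within the scatter. Compound 3 `Cc1ccc(NC(=O)Nc2ccc(-c3nc(NCCCN(C)C)c4sc(Cl)c(Cl)c4n3)cc2)cc1` differs from compound 2 by 4-methylphenyl in place of 2,4-dichlorophenyl on an amide-type nitrogen. Among the measured compounds shown here, only that one measured step bears on this change, and it was small. He therefore expects no step beyond the scatter. Compound 3 is expected to give 1000 nM, in the range 400 nM to 2500 nM. The estimated step is a 1.3-fold lower number from compound 2 to compound 3 (0.12 log units; within the scatter).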

Compound 3, half-maximal inhibitory concentration: 1320 nM
Beside the measured number, compound 3's estimate is 1.3-fold (0.12 log units) below it, within the range that was stated.
By their numbers in this assay, from the lowest: compounds 1, 2 and 3 (each within the scatter of the next).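

In this assay, 4-methylphenyl in place of 2,4-dichlorophenyl on the amide-type nitrogen gives no change at the digits printed from compound 2 to compound 3 (within the scatter), while 4-methylphenyl in place of 2-chlorophenyl gives a 1.6-fold higher number from compound 1 to compound 3 (0.21 log units; within the scatter). The earlier compounds shown here carried only chloro-substituted rings here, whereas compound 3 shows that a ring without chlorine also stays within the scatter of both. No available evidence explains this result. Going by these compounds, the three rings carry only chloro or methyl groups, so it remains open whether a methoxy group, an amine or a carboxylic acid on this ring would give a step beyond the scatter. On these data alone, replacing the ring with a hexyl chain also remains untested here.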